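This account rests on a few compounds, and the source may have more. Where it says the series, first, only, none or still open, it means among the compounds named here.

Compound 1 `CCCCOc1ccc(C[C@H]2C(=O)OC[C@@H]2Cc2ccccc2)cc1`: 23000 nM
Compound 2 `Clc1ccc(C[C@H]2COC[C@@H]2Cc2ccccc2)cc1Cl`: 19000 nM
Compound 3 `COc1cc(C[C@H]2COC(=O)[C@@H]2Cc2ccc(Cl)c(Cl)c2)ccc1O`: 36000 nM

These three compounds were tested in a functional assay on HL-60 cells (Homo sapiens) for cytotoxicity, read by WST assay, with a stated time of 48 h; a higher number here means that more compound is needed for the effect, a lower number that less compound is needed. There, compound 2 gives 19000 nM, which lies within the usual scatter of both other values, so the three numbers cannot be ranked. All three compounds need a comparably high concentration for the effect.

The next compound is compound 4 `Cc1ccccc1C[C@H]1COC[C@@H]1Cc1ccc(Cl)c(Cl)c1`, which has not yet been measured. Its structure departs from that of compound 2 in one place: methyl in place of hydrogen on an aromatic carbon. In words, this is methyl in place of hydrogen on an aromatic carbon, which turns a phenyl into a 2-methylphenyl.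

Going by the values given here, no measured pair differs in just one place, so the data hold no direct precedent for this change. Among the compounds with values here, the only guide is indirect. Compound 1 at 23000 nM and compound 3 at 36000 nM both differ from compound 2 in more than one place, yet both remain within the scatter of it. A single added methyl is therefore expected to move the number little, with no clear direction in this assay. The estimated step of a 1.1-fold lower number from compound 2 to compound 4 (0.02 log units; within the scatter) stays within the scatter.

For compound 4 the expected value is 18000 nM, with an estimated range from 7000 nM to 42000 nM.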

Compound 4, half-maximal effective concentration: 21000 nM
For compound 4 the middle estimate is 1.2-fold (0.07 log units) below the measured one; measured number inside the range.
By their numbers in this assay, from the lowest: compounds 2, 4, 1 and 3 (each within the scatter of the next).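

Going by these compounds alone, the step of a 1.1-fold higher number from compound 2 to compound 4 (0.04 log units; within the scatter) in this assay gives the first direct reading of this change, which the earlier compounds could only suggest indirectly. On an aromatic carbon ortho to a large group, methyl in place of hydrogen turns the phenyl into a 2-methylphenyl, and the two compounds cannot be told apart by their numbers. This single pair therefore shows that this position can carry this one added carbon with no readable shift in this assay, though it shows nothing about any other substituent there. Nothing available explains this outcome or bears on it beyond the numbers themselves.

The compounds shown leave open whether a larger or different group at this same place, such as an ethyl, a methoxy, a chlorine or an amine, would also stay within the scatter, and whether the methyl would do so elsewhere on that ring. They also leave open whether the same methyl would give so small a step on a core that carries a carbonyl, like the core of compound 1 and that of compound 3.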